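The compounds below may be only part of what the source reports. "The series", "measured", "known", "first", "only" and "open" are said of these compounds alone.

Compounds measured in a functional assay on HeLa cells (Homo sapiens) for antiproliferative activity, read by sulforhodamine B assay, with a stated time of 48 h; a higher number here means a weaker inhibitor, a lower number a stronger inhibitor:
compound 1 `NS(=O)(=O)c1ccc(N/C(S)=N\c2ccnc3cc(C(F)(F)F)ccc23)cc1`, which gives 36600 nM
compound 2 `N=C(N)NS(=O)(=O)c1ccc(N/C(S)=N\c2ccnc3cc(C(F)(F)F)ccc23)cc1`, which gives 23900 nM
compound 3 `Cc1ccnc(NS(=O)(=O)c2ccc(N/C(S)=N\c3ccnc4cc(C(F)(F)F)ccc34)cc2)n1`, which gives 31000 nM

Compound 2 has the lowest of the three numbers, but neither neighbour is separated from it beyond the scatter: a 1.5-fold lower number from compound 1 to compound 2 (0.19 log units; within the scatter) and a 1.3-fold higher number from compound 2 to compound 3 (0.11 log units; within the scatter). The third pair behaves the same way, with a 1.2-fold lower number from compound 1 to compound 3 (0.07 log units; within the scatter). All three changes sit on the sulfonamide nitrogen of the shared core, and none of them moves the read-out.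

Compound 4 `Cc1cc(C)nc(NS(=O)(=O)c2ccc(N/C(S)=N\c3ccnc4cc(C(F)(F)F)ccc34)cc2)n1` differs from compound 2 in the same place: a group of 8 heavy atoms (6 carbon, 2 nitrogen; one six-membered aromatic ring with 2 hetero atoms) in place of a group of 3 heavy atoms (1 carbon, 2 nitrogen; no ring), on a sulfonamide nitrogen. For the measured compounds named here, the closest precedent is the step from compound 2 to compound 3, where a 4-methylpyrimidin-2-yl took the place of the same three-atom group and the number stayed within the scatter. Going by the values given here, compound 4 carries one further methyl on that ring, and nothing among the measured steps suggests that a substituent on this nitrogen shifts the read-out. Compound 4 is therefore expected to give 30000 nM, with a range of 15000 nM to 60000 nM. That estimate means a 1.3-fold higher number from compound 2 to compound 4 (0.10 log units; within the scatter), a step expected to lie within the scatter.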

Compound 4, half-maximal inhibitory concentration: 33000 nM
Compound 4: middle estimate off by 1.1-fold (0.04 log units), on the low side, within the range that was stated.
By their numbers in this assay, from the lowest: compounds 2, 3, 4 and 1 (each within the scatter of the next).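

With compound 4, the sulfonamide nitrogen now carries a ring with two methyl groups, and the read-out still does not separate it from the others: hydrogen gives way to 4,6-dimethylpyrimidin-2-yl with a 1.1-fold lower number from compound 1 to compound 4 (0.04 log units; within the scatter) and the group of 3 heavy atoms gives way to it with a 1.4-fold higher number from compound 2 to compound 4 (0.14 log units; within the scatter) as the result. The change not seen before, methyl in place of hydrogen on an aromatic carbon of that ring, gives a 1.1-fold higher number from compound 3 to compound 4 (0.03 log units; within the scatter) and so adds no measurable difference. Nothing available here accounts for this flat behaviour.

Going by these compounds, all four compounds vary only on this nitrogen, so it remains open whether a carboxylic acid or a longer alkyl chain there would behave the same way. On these data alone, it is also open whether an amine in place of the trifluoromethyl on the shared core would move the read-out.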